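Terminal Alkene on a Lengthened Ester Chain of Compound 3

This account rests on a few compounds, and the source may have more. Where it says the series, first, only, none or still open, it means among the compounds named here.

Measured compounds:
compound 1 `CCCCCCCCCC(=O)O[C@H]1[C@H](O)[C@H](n2ccc(N)nc2=O)O[C@@H]1CO` — 0.09 ug/mL
compound 2 `CCCCCCCCCCCCCCCC(=O)O[C@H]1[C@H](O)[C@H](n2ccc(N)nc2=O)O[C@@H]1CO` — 0.24 ug/mL
compound 3 `CCCCCC(=O)O[C@H]1[C@H](O)[C@H](n2ccc(N)nc2=O)O[C@@H]1CO` — 0.05 ug/mL

In a functional assay on HeLa cells (Homo sapiens) for cytotoxicity, read by cell counting, with a stated time of 48 h (on this read-out higher numbers stand for an effect only at larger amounts of compound and lower numbers for an effect already at smaller amounts), compound 3 gives the lowest of the three numbers. Its nearest neighbour is compound 1, reached by a 1.8-fold lower number from compound 1 to compound 3 (0.26 log units; within the scatter), a step that lies within the scatter. The furthest is compound 2, separated by a 4.8-fold lower number from compound 2 to compound 3 (0.68 log units; beyond the scatter), which goes beyond it.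

Compound 4 `C=CCCCCCCCCC(=O)O[C@H]1[C@H](O)[C@H](n2ccc(N)nc2=O)O[C@@H]1CO` arises from compound 3 by pent-4-en-1-yl in place of hydrogen on a saturated chain carbon, five bonds along the chain from a carbonyl carbon. The measured steps at this same place are the butyl-to-hydrogen change in a 1.8-fold lower number from compound 1 to compound 3 (0.26 log units; within the scatter) and the decyl-to-hydrogen change in a 4.8-fold lower number from compound 2 to compound 3 (0.68 log units; beyond the scatter); both show that a longer ester chain brings a higher number, small for the shorter addition and modest for the longest one. Going the other way, in a 2.7-fold higher number from compound 1 to compound 2 (0.43 log units; beyond the scatter), the chain extension again raised the number. Pent-4-en-1-yl is closer in size to butyl than to decyl, so for compound 4 an upward step near the within-scatter size is expected, a 2.0-fold higher number from compound 3 to compound 4 (0.30 log units; within the scatter). Compound 4 is therefore estimated at 0.1 ug/mL, with a range from 0.04 ug/mL to 0.25 ug/mL.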

Compound 4, concentration for half-maximal effect: 0.05 ug/mL
For compound 4 the middle estimate is 2.0-fold (0.30 log units) above the measured one; low and high end bracket the measured number.
By their numbers in this assay, from the lowest: compounds 3, 4 and 1 (each within the scatter of the next); then compound 2.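

In this assay, pent-4-en-1-yl at this place on the saturated chain, five bonds along from the carbonyl carbon, gives no change at the digits printed from compound 3 to compound 4 (within the scatter), so this lengthening of the ester chain of compound 3, ending in a double bond, leaves the number where it was. The change of methyl to vinyl, in a 1.8-fold lower number from compound 1 to compound 4 (0.26 log units; within the scatter), also stays within the scatter, whereas vinyl in place of heptyl gives a 4.8-fold lower number from compound 2 to compound 4 (0.68 log units; beyond the scatter), which leaves compound 2 as the only one of the four set apart by steps beyond the scatter. No measurement at hand explains why this chain behaves as it does.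

The compounds shown leave open what the terminal double bond itself contributes, as none carries a saturated chain of the same length as that of compound 4. They also leave open whether a terminal alkyne or a terminal hydroxyl on this chain would fall with compound 1, compound 3 and compound 4 or with compound 2.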